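The compounds below may be only part of what the source reports. "The series", "measured", "known", "first", "only" and "open" are said of these compounds alone.

Measured compounds:
- compound 1, `Nc1scc(CN2CCN(c3ccc(OC(F)(F)F)cc3)CC2)c1C(=O)c1ccc(Cl)cc1`: 0%
- compound 2, `Nc1scc(CN2CCN(c3ccc(C(F)(F)F)cc3)CC2)c1C(=O)c1cccc(C(F)(F)F)c1`: -12%
- compound 3, `Nc1scc(CN2CCN(c3c(F)cccc3F)CC2)c1C(=O)c1cccc(C(F)(F)F)c1`: 2.1%

In a functional assay on CHO cells with adenosine receptor A1 (Homo sapiens) as the target, read by cAMP accumulation and immunoassay, with a stated time of 6 min, tested at 0.01 uM (a lower number here means a stronger effect, a higher number a weaker effect of the compound at the concentration tested), compound 1 gives 0%, the second highest of the three numbers. Compound 3 is nearest to it and the gap between the two lies within the scatter; compound 2 is furthest, with a lower number beyond the scatter. Going by the values given here, only one single-point step has been measured, a number 14.1 percentage points higher from compound 2 to compound 3 (beyond the scatter), and it exchanges the aryl group on the amine nitrogen in the ring, the same place that is changed here.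

Compound 4, `Nc1scc(CN2CCN(c3ccccc3Cl)CC2)c1C(=O)c1ccc(Cl)cc1`, is not yet measured. Relative to compound 1 it carries 2-chlorophenyl in place of 4-(trifluoromethoxy)phenyl on an amine nitrogen in a ring. Among the compounds with values here, the one measured step at this position was modest, and all three measured numbers sit near zero at this concentration, so no step beyond the scatter is expected; the estimate amounts to a number 2 percentage points higher from compound 1 to compound 4 (within the scatter). Compound 4 is therefore expected at about 2%, within a range of -12% to 16%.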

Compound 4, a percentage reported as activity, at one concentration (the size of the read-out at that concentration, not a potency): -2.1%
Estimate against measurement, compound 4: 4.1 percentage points above; the range from low to high includes it.
By their numbers in this assay, from the lowest: compounds 2, 4, 1 and 3 (each within the scatter of the next, the first and the last beyond it).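

In this assay, 2-chlorophenyl in place of 4-(trifluoromethoxy)phenyl on the amine nitrogen in the ring gives a number 2.1 percentage points lower from compound 1 to compound 4 (within the scatter), so on the core of compound 1 this position tolerates a group with fewer heavy atoms without a step beyond the scatter. Unlike a number 14.1 percentage points higher from compound 2 to compound 3 (beyond the scatter), this second step at the position shows that an exchange of aryl groups here need not move the number beyond the scatter, although the two steps share neither their aryl groups nor the rest of the molecule. No available measurement explains why this step stays so small.

Going by these compounds, whether an unsubstituted phenyl, a benzyl or a cyclohexyl group on that nitrogen would stay within the scatter of compound 1 remains open. The single concentration also leaves open how these compounds would differ in potency.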